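Oxazolyl ketone series: methyl position on the pyridyl ring

A few compounds are considered here, and "the series" means these few. Any claim that something is new, unique, unknown or untested is made for them only; others in the source may bear on it.

Values in an assay (Rattus norvegicus) for inhibition of Fatty-acid amide hydrolase 1 (Homo sapiens) (a higher number here means a weaker inhibitor, a lower number a stronger inhibitor), so far:
compound 1 `N#Cc1ccccc1-c1cnc(C(=O)CCCCCCc2ccccc2)o1`: 130 nM
compound 2 `O=C(CCCCCCc1ccccc1)c1ncc(-c2ccc(F)cc2)o1`: 62 nM
compound 3 `Cc1cccnc1-c1cnc(C(=O)CCCCCCc2ccccc2)o1`: 15 nM

Compound 3 gives the lowest number of the three. Its nearest neighbour is compound 2, with a 4.1-fold lower number from compound 2 to compound 3 (0.62 log units; beyond the scatter), and the furthest is compound 1, with an 8.7-fold lower number from compound 1 to compound 3 (0.94 log units; beyond the scatter); the remaining measured step is a 2.1-fold lower number from compound 1 to compound 2 (0.32 log units; beyond the scatter). Both steps beyond the scatter therefore lie between compound 3 and the rest.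

Compound 4 `Cc1cccc(-c2cnc(C(=O)CCCCCCc3ccccc3)o2)n1` is not yet measured. It differs from compound 3 in one place: 6-methylpyridin-2-yl in place of 3-methylpyridin-2-yl on an aromatic carbon. The two have the same atoms, joined differently; the methyl moves from one position of the pyridyl ring to another.

None of the three measured steps bears directly on this change. Each of them exchanges the whole aryl group for a different one, whereas the step from compound 3 to compound 4 keeps the pyridyl ring and relocates only the methyl. The measured steps show that the aryl group matters to this assay, but give no guide to the direction of a change inside the same ring. The expected step of a 1.7-fold higher number from compound 3 to compound 4 (0.22 log units; within the scatter) is therefore set close to zero, with a wide range. For compound 4 the estimate in this assay is 25 nM, with a range from 8 nM to 80 nM.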

Compound 4, inhibition constant: 3.3 nM
The estimate for compound 4 lay 7.6-fold (0.88 log units) above the measured number; measured number outside the range, below it.
By their numbers in this assay, from the lowest: compound 4; then compound 3; then compound 2; then compound 1.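

Within a single pyridyl ring, the place of the methyl is enough to shift the number in this assay: moving it gives a 4.5-fold lower number from compound 3 to compound 4 (0.66 log units; beyond the scatter), although the atoms that leave and enter are counted the same, so changes inside this aryl group, and not only exchanges of the whole group, register in this assay. Against the other aryl groups the gain widens, with a 19-fold lower number from compound 2 to compound 4 (1.27 log units; beyond the scatter) and a 39-fold lower number from compound 1 to compound 4 (1.60 log units; beyond the scatter), both large, which makes 6-methylpyridin-2-yl the group with the lowest number of the four, its steps to all three others lying beyond the scatter. Nothing at hand accounts for the difference between the two methyl placements.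

The unsubstituted pyridin-2-yl group would be needed to show whether the methyl in 6-methylpyridin-2-yl lowers the number at all or the methyl in 3-methylpyridin-2-yl raises it, and the 4-methylpyridin-2-yl and 5-methylpyridin-2-yl isomers would complete the positional picture. Going by these compounds, it also remains open whether an ethyl, methoxy or chloro group in place of that methyl would hold the number of compound 4.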